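The source may report more compounds than this note shows. Statements on the series, on what has been measured and on what is new or still open speak of the compounds shown alone.

Measured so far:
compound 1 `COc1cc2nc(N3CCN(C(=O)c4ccc(C(F)(F)F)cc4)CC3)nc(N)c2cc1OC` — > 100000 nM in a functional assay on PC-3 cells (Homo sapiens) for inhibition; a lower number here means a stronger inhibitor, a higher number a weaker inhibitor
compound 2 `COc1cc2nc(N3CCN(S(=O)(=O)c4ccc(C(F)(F)F)cc4)CC3)nc(N)c2cc1OC` — 27000 nM in this assay

For compound 1 the value > 100000 nM is a limit of this assay and not a number (the limit of > 100000 nM in this assay, at which 1 of the 2 values shown sits). Within the data shown here, compound 2 thus carries the only number in this assay so far. Compound 3 `COc1cc2nc(N3CCN(S(=O)(=O)c4ccc5ccccc5c4)CC3)nc(N)c2cc1OC` differs from compound 2 by naphthalen-2-yl in place of 4-(trifluoromethyl)phenyl on a sulfonyl sulfur. Among the measured compounds shown here, no step between two measured compounds is available, so the size of this change cannot be read from the series. A step of a 1.4-fold lower number from compound 2 to compound 3 (0.13 log units; within the scatter) is expected, not clearly beyond the usual scatter. In this assay compound 3 is estimated at 20000 nM, between 5000 nM and 80000 nM.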

Compound 3, half-maximal inhibitory concentration: 15000 nM
Compound 3: the middle estimate sits 1.3-fold (0.12 log units) above what was measured; measured number inside the range.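

On a sulfonyl sulfur, naphthalen-2-yl in place of 4-(trifluoromethyl)phenyl gives a 1.8-fold lower number from compound 2 to compound 3 (0.26 log units; within the scatter) in this assay. Among these compounds, this is the first readable step: exchanging one aromatic ring bearing trifluoromethyl for two fused aromatic rings of carbon only does not move the number beyond the scatter. Neither aryl group is separated from the other here.

Going by these compounds, whether an alkyl chain or an aryl group carrying an amine or a carboxylic acid on the sulfonyl sulfur would shift the number beyond the scatter remains open. One value in the series is still a limit and not a number: the limit of > 100000 nM in this assay, at which 1 of the 3 values shown sits.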